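Swapping 1,3-thiazol-2-yl for thiophen-2-yl in Compound 3

The source may report more compounds than this note shows. Statements on the series, on what has been measured and on what is new or still open speak of the compounds shown alone.

Of the compounds shown here, three have been measured in an assay for inhibition of Catechol O-methyltransferase (Rattus norvegicus), read by fluorescence and spectrophotometry; a lower number here means a stronger inhibitor, a higher number a weaker inhibitor. Compound 1 `O=C(/C=C/c1cccs1)c1cc(O)c(O)c([N+](=O)[O-])c1` gives 190 nM, compound 2 `O=C(/C=C/c1cccc(O)c1)c1cc(O)c(O)c([N+](=O)[O-])c1` gives 140 nM, and compound 3 `CC(=O)N1N=C(c2cc(O)c(O)c([N+](=O)[O-])c2)CC1c1nccs1` gives 160 nM. The number for compound 3 lies between those of compound 2 and compound 1, and both gaps are within the usual scatter, so the three cannot be ranked against one another.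

Compound 4 `CC(=O)N1N=C(c2cc(O)c(O)c([N+](=O)[O-])c2)CC1c1cccs1` is the next compound to be measured. It differs from compound 3 in one place: thiophen-2-yl in place of 1,3-thiazol-2-yl on a saturated ring carbon.

Among the measured compounds shown here, only one measured step is available, and it bears on this change loosely at best. In a 1.4-fold lower number from compound 1 to compound 2 (0.13 log units; within the scatter) a thiophen-2-yl group was exchanged on a chain carbon of a different core, against a 3-hydroxyphenyl group rather than a 1,3-thiazol-2-yl group, and the change stayed within the scatter. For the measured compounds named here, no measured pair exchanges 1,3-thiazol-2-yl for thiophen-2-yl, so nothing in the data points to a shift in either direction. For compound 4 the expected step is therefore no change at the digits printed from compound 3 to compound 4 (within the scatter), none beyond the scatter. Compound 4 is estimated at 160 nM, with a range from 70 nM to 360 nM.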

Compound 4, half-maximal inhibitory concentration: 210 nM
Compound 4: the middle estimate sits 1.3-fold (0.12 log units) below what was measured; low and high end bracket the measured number.
By their numbers in this assay, from the lowest: compounds 2, 3, 1 and 4 (each within the scatter of the next).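

In this assay, among the compounds shown here, this exchange on a saturated ring carbon gives a 1.3-fold higher number from compound 3 to compound 4 (0.12 log units; within the scatter) and is the first direct comparison of 1,3-thiazol-2-yl with thiophen-2-yl in the shared core. It shows that this position accepts either five-membered aromatic ring with no difference that can be told from the scatter, even though the entering group has 1 hydrogen-bond acceptor where the leaving group has 2 and a carbon in place of the ring nitrogen. Nothing available gives a measured reason for the size of this step, and with a step this small there is little to explain.

Both groups at this position are five-membered aromatic rings of the same heavy-atom size, so the compounds shown say nothing about how a very different group on that saturated ring carbon, such as a primary amine, a carboxylic acid or a longer alkyl chain, would change the number. They also leave open whether the acetyl group on the neighbouring ring atom matters, since it stays the same in both compounds, and a formyl or benzoyl group there could give a different picture.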